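This account rests on a few compounds, and the source may have more. Where it says the series, first, only, none or still open, it means among the compounds named here.

Of the compounds shown here, three built on a shared core have been tested in a functional assay on the whole organism (strain albino) for inhibition, with Rattus norvegicus as the target, read by paw edema, with stated times of 1 h and 3 h, at a dose of 20 mmol/kg by the intraperitoneal route; a higher number here means a stronger effect of the compound at the dose given, a lower number a weaker effect. Compound 1 `N#CC1=C(NCN2CCCCC2)N(c2ccccc2)C(=O)N2CCCCC(N3CCCC3)C12` gives 42.1% in this assay. Compound 2 `N#CC1=C(/N=C/Nc2ccccc2)N(c2ccccc2)C(=O)N2CCCCC(N3CCCC3)C12` gives 79.3%. Compound 3 `N#CC1=C(NCN2CCCC2)N(c2ccccc2)C(=O)N2CCCCC(N3CCCC3)C12` gives 35.3%, the lowest of the three numbers; compound 1 is the closest to it, with a gap inside the scatter, while compound 2 stands far above it. The measured steps show a number 37.2 percentage points higher from compound 1 to compound 2 (beyond the scatter) and a number 44 percentage points lower from compound 2 to compound 3 (beyond the scatter), whereas a number 6.8 percentage points lower from compound 1 to compound 3 (within the scatter).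

Compound 4 `N#CC1=C(/N=C/c2ccc([N+](=O)[O-])cc2)N(c2ccccc2)C(=O)N2CCCCC(N3CCCC3)C12` has not yet been measured. It differs from compound 3 in one place: a group of 11 heavy atoms (7 carbon, 2 nitrogen, 2 oxygen; one six-membered aromatic ring of carbon only) in place of a group of 7 heavy atoms (5 carbon, 2 nitrogen; one five-membered non-aromatic ring with 1 hetero atom), on a double-bonded ring carbon. The two large steps bear on this change: each of them joins a compound carrying a six-membered aromatic ring of carbon only on that double-bonded ring carbon with one carrying a non-aromatic ring there, and in both the aromatic one came out well above. A step upward beyond the scatter is therefore expected, a number 34.7 percentage points higher from compound 3 to compound 4 (beyond the scatter). For compound 4 the estimate in this assay is 70%, with an expected range from 50% to 88%.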

Compound 4, a percentage reported as inhibition, in the whole organism at one dose (the size of the read-out at that dose, not a potency): 91.7%
Beside the measured number, compound 4's estimate is 21.7 percentage points below it; measured number above the stated range.
By their numbers in this assay, from the lowest: compounds 3 and 1 (each within the scatter of the next); then compound 2; then compound 4.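

In this assay the 4-nitrophenyl group on a carbon with a double bond to nitrogen goes past the anilino group, with a number 12.4 percentage points higher from compound 2 to compound 4 (beyond the scatter) in that exchange, so compound 4 now holds the highest number of the four. The group that enters counts no hydrogen-bond donors, so a strong effect at this position does not depend on a donor in that group. Against the saturated rings the gain is large, with a number 56.4 percentage points higher from compound 3 to compound 4 (beyond the scatter) and a number 49.6 percentage points higher from compound 1 to compound 4 (beyond the scatter) on the same double-bonded ring carbon, and both compounds carrying a six-membered aromatic ring of carbon only there stand above both carrying a non-aromatic ring.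

From the compounds shown here alone, how an unsubstituted phenyl, a 4-methoxyphenyl or a 4-aminophenyl would compare on that carbon remains open. Nothing shown accounts for the size of these steps.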